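Benzyl to cyclohexyl on the imidazole-type ring: expected step

This account rests on a few compounds, and the source may have more. Where it says the series, first, only, none or still open, it means among the compounds named here.

The pair measured so far shares one core. Compound 1 `O=C(O)c1ccccc1-c1ccc(CCc2ncc(Cc3cccc(Cl)c3)[nH]2)cc1` in an in vitro functional assay on cells for agonist activity at Bombesin receptor subtype-3 (Mus musculus), read by luminescence and calcium flux (a lower number here means that less compound is needed, a higher number that more compound is needed for the effect), gives 31 nM. Among the measured compounds shown here, compound 2 `O=C(O)c1ccccc1-c1ccc(CCc2ncc(Cc3ccccc3)[nH]2)cc1` gives 11 nM, the lowest number of the two, and the only step known, a 2.8-fold lower number from compound 1 to compound 2 (0.45 log units; beyond the scatter), is a modest gain from removing chloro on an aromatic carbon. Compound 3 `O=C(O)c1ccccc1-c1ccc(CCc2ncc(C3CCCCC3)[nH]2)cc1` is not yet measured; it differs from compound 2 by cyclohexyl in place of benzyl on an aromatic carbon. For the measured compounds named here, no measured step bears directly on this change: the one step available alters a substituent on the benzyl, whereas here the whole benzyl gives way to cyclohexyl on the five-membered aromatic ring with two nitrogen. Given that compound 2 sits at 11 nM and that the series has so far tolerated only a small edit there, a modest rise in the number is expected, a 2.7-fold higher number from compound 2 to compound 3 (0.44 log units; beyond the scatter). For compound 3 the expected value is 30 nM, in a range from 8 nM to 120 nM.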

Compound 3, half-maximal effective concentration: 14.7 nM
Compound 3: the middle estimate sits 2.0-fold (0.31 log units) above what was measured; low and high end bracket the measured number.
By their numbers in this assay, from the lowest: compounds 2 and 3 (each within the scatter of the next); then compound 1.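

In this assay, this position on the five-membered aromatic ring takes a far larger edit than the chloro removal did: a 1.3-fold higher number from compound 2 to compound 3 (0.13 log units; within the scatter) while one six-membered aromatic ring of carbon only gives way to a six-membered non-aromatic ring of carbon only, so for this pair an aromatic ring in the group is not needed to stay within the scatter. Cyclohexyl also compares well with the chlorinated group, with a 2.1-fold lower number from compound 1 to compound 3 (0.32 log units; beyond the scatter) on replacing 3-chlorobenzyl, so the benzyl of compound 2 is not unique in reaching this range. No measurement offers an explanation for this tolerance.

On these data alone, a phenyl set directly on the same carbon and an open-chain group such as tert-butyl remain open. So does a cyclohexyl carrying an amine or a hydroxyl.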